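Aryl swap on the ring nitrogen of the shared core

The source may hold more compounds than are shown below. What is called first, only, known or untested is meant among the compounds shown, and "the series" means these compounds.

Of the compounds shown here, two have numbers so far. In an assay on cells for displacement of a labelled ligand from corticotropin-releasing factor receptor 1 (Homo sapiens), with a stated time of 100 min (on this read-out lower numbers stand for stronger inhibition and higher numbers for weaker inhibition), compound 1 `CCCN(Cc1ccccc1)Cc1c(C(F)(F)F)nc2n(-c3c(C)cc(C)cc3C)c(Cl)cn12` gives 170 nM and compound 2 `CCCN(Cc1c(C(F)(F)F)nc2n(-c3c(C)cc(C)cc3Cl)c(Cl)cn12)CC1CC1` gives 4.2 nM. Compound 2 holds the lowest of the two numbers; compound 1 stands at a higher number, beyond the scatter. Within the data shown here, the two differ in more than one place, so no single step between measured compounds can be counted, and only the two values themselves are known.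

Compound 3 `CCCN(Cc1c(C(F)(F)F)nc2n(-c3ccc(OC)cc3C)c(Cl)cn12)CC1CC1` is not yet measured. It differs from compound 2 as follows: 4-methoxy-2-methylphenyl in place of 2-chloro-4,6-dimethylphenyl on an aromatic nitrogen. Among the measured compounds shown here, no measured step of this kind exists to lean on. The expectation is a move toward a higher number, of moderate size, given as a 7.1-fold higher number from compound 2 to compound 3 (0.85 log units; beyond the scatter) from compound 2 to compound 3. For compound 3 the estimate in this assay is 30 nM, with a range from 8 nM to 150 nM.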

Compound 3, inhibition constant: 13 nM
Compound 3: the middle estimate sits 2.3-fold (0.36 log units) above what was measured; the range from low to high includes it.
By their numbers in this assay, from the lowest: compound 2; then compound 3; then compound 1.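

In this assay the series now has its first countable step at this position, on an aromatic nitrogen of the shared core: a 3.1-fold higher number from compound 2 to compound 3 (0.49 log units; beyond the scatter). The change from 2-chloro-4,6-dimethylphenyl to 4-methoxy-2-methylphenyl keeps the heavy-atom count of the group but replaces chlorine with oxygen and adds one hydrogen-bond acceptor, and compound 3 still stands at 13 nM, so this substitution on the aryl group is compatible with a low number. No measurement at hand accounts for the size of the step.

On these data alone, the step changes several substituents on the aryl group at once, so the share of each remains open. Also open, as far as these compounds go, is how a dimethylamino group or a carboxylic acid in place of the methoxy group would stand on this read-out.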